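The compounds below may be only part of what the source reports. "The series", "measured", "known", "first", "only" and "open" are said of these compounds alone.

Of the compounds shown here, three built on a shared core have been measured in a toxicity assay on MDCK cells (Canis lupus familiaris) for cytotoxicity, read by crystal violet staining, with a stated time of 48 h; on this read-out lower numbers stand for higher toxicity in this test and higher numbers for lower toxicity in this test. Compound 2 `Cc1ccc2[nH]c(=O)c(CN(CCCO)Cc3ccc(C(C)(C)C)cc3)cc2c1` gives only a limit in this assay, > 10000 nM. Compound 3 `CCc1ccc2[nH]c(=O)c(CN(CCCO)Cc3ccc(C(C)(C)C)cc3)cc2c1` likewise gives only a limit, > 10000 nM. Compound 1 `CCc1ccc2cc(CN(Cc3ccc(C(C)(C)C)cc3)C3CCCC3)c(=O)[nH]c2c1` also gives only a limit, > 9000 nM. For the measured compounds named here, the single step among them, a step that the two limits leave unreadable from compound 2 to compound 3, has no readable size; the limit of > 10000 nM in this assay, at which 2 of the 3 values shown sit, marks where both of its ends sit, and the limit of > 9000 nM in this assay, at which 1 of the 3 values shown sits, marks where the remaining value sits. Compound 4 `CCCCOc1ccc(CN(Cc2ccc(C(C)(C)C)cc2)Cc2cc3cc(C)ccc3[nH]c2=O)cc1` differs from compound 2 by 4-butoxyphenyl in place of 2-hydroxyethyl on a saturated chain carbon bound to an amine nitrogen. Going by the values given here, no measured step covers this change, and every value so far sits at a limit, so no step beyond the scatter is expected in this assay. Compound 4 is therefore expected to give 12000 nM, within 5000 nM to 40000 nM, an expected step that the limit leaves unreadable from compound 2 to compound 4.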

Compound 4, half-maximal cytotoxic concentration: > 5000 nM
Compound 4: no number, only a limit (the forecaster's own chance of this, stated with the estimate: 80%); the middle value lies beyond the limit too.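

For the compounds shown here, compound 2 and compound 4 each give only a limit, so no step between them can be read. The compounds shown leave open the actual half-maximal cytotoxic concentration of each, and whether 4-butoxyphenyl in place of 2-hydroxyethyl changes it.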